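A few compounds are considered here, and "the series" means these few. Any claim that something is new, unique, unknown or untested is made for them only; others in the source may bear on it.

Measured compounds:
Compound 1, `CCOc1ccccc1N1CCN(CCn2nc(-c3ccc(C)cc3)c3ccccc3c2=O)CC1`, in an assay on Cerebral cortex for displacement of a labelled ligand from Adrenergic receptor alpha-1 (Rattus norvegicus) (on this read-out lower numbers stand for stronger inhibition and higher numbers for weaker inhibition), compound 1 gives 3.9 nM.
Compound 2, `COc1ccccc1N1CCN(CCCCn2nc(-c3ccc(C)cc3)c3ccccc3c2=O)CC1`, in this assay compound 2 gives 2.6 nM.

The two values for compound 1 and compound 2 lie within the scatter of each other, so the numbers alone do not separate them, and compound 2 simply sits alongside compound 1 at the potent end of what has been measured.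

Compound 3, `Cc1ccc(-c2nn(CCCCN3CCN(CC4COc5ccccc5O4)CC3)c(=O)c3ccccc23)cc1`, has not yet been measured. It differs from compound 2 in one place: (2,3-dihydro-1,4-benzodioxin-2-yl)methyl in place of 2-methoxyphenyl on an amine nitrogen in a ring. Among the measured compounds shown here, no measured pair shows the effect of this kind of exchange, so the expectation for compound 3 rests only on the step itself being a replacement of one large group by another on the same ring nitrogen. The estimate for compound 3 is a step of a 1.9-fold higher number from compound 2 to compound 3 (0.28 log units; within the scatter), a shift that need not exceed the scatter. The value for compound 3 is therefore expected to be 5 nM, likely between 1.5 nM and 20 nM.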

Compound 3, inhibition constant: 180 nM
The estimate for compound 3 lay 36-fold (1.56 log units) below the measured number; measured number outside the range, above it.
By their numbers in this assay, from the lowest: compounds 2 and 1 (each within the scatter of the next); then compound 3.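

In this assay, the amine nitrogen in the ring proves not to be a place where one large group can simply replace another: (2,3-dihydro-1,4-benzodioxin-2-yl)methyl in place of 2-methoxyphenyl gives a 69-fold higher number from compound 2 to compound 3 (1.84 log units; beyond the scatter). Compound 1 and compound 2 both carry a benzene ring with an oxygen-linked group on that nitrogen, so they could not show how much this position matters for inhibition. Nothing available here explains the loss of inhibition.

The entering group differs from the leaving group in several ways at once, including its added non-aromatic ring, its extra heavy atoms and its hydrogen-bond acceptor count, and this single step cannot separate them. As far as these compounds go, whether a plain benzyl or a 2-pyridyl group on the same nitrogen would keep the low number remains open.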